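A Methyl Group on the Cyclopropyl Ring

The compounds below may be only part of what the source reports. "The series", "measured", "known", "first", "only" and "open" are said of these compounds alone.

In an ADME assay on the whole organism for metabolic stability, with Rattus norvegicus as the target, read by LC-MS (on this read-out lower numbers stand for a shorter-lived compound and higher numbers for a longer-lived compound), compound 1 (`Cc1cc(C(=O)N[C@H]2CCCCC/C=C\[C@@H]3C[C@@]3(C(=O)NS(=O)(=O)C3CC3)NC(=O)[C@@H]3C[C@@H](Oc4nc5ccccc5nc4C(F)(F)F)CN3C2=O)no1`) gives 1.8 h and compound 2 (`Cc1cc(C(=O)N[C@H]2CCCCC/C=C\[C@@H]3C[C@@]3(C(=O)NS(=O)(=O)C3CC3)NC(=O)[C@@H]3C[C@@H](Oc4nc5cc(F)ccc5nc4C(F)(F)F)CN3C2=O)no1`) gives 1.9 h as its reading. For the measured compounds named here, the only measured step, a 1.1-fold higher number from compound 1 to compound 2 (0.02 log units; within the scatter) for fluoro in place of hydrogen on an aromatic carbon, leaves compound 2 level with compound 1. Compound 3 (`Cc1cc(C(=O)N[C@H]2CCCCC/C=C\[C@@H]3C[C@@]3(C(=O)NS(=O)(=O)C3(C)CC3)NC(=O)[C@@H]3C[C@@H](Oc4nc5cc(F)ccc5nc4C(F)(F)F)CN3C2=O)no1`) differs from compound 2 by methyl in place of hydrogen on a saturated ring carbon and turns cyclopropylsulfonyl into (1-methylcyclopropyl)sulfonyl. Going by the values given here, no measured step touches that place, so no step beyond the scatter is expected in this assay here. The estimated change is a 1.1-fold higher number from compound 2 to compound 3 (0.04 log units; within the scatter) in all. Compound 3 is expected at 2.1 h with 1 h to 4.2 h as its estimated range.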

Compound 3, half-life: 4.7 h
Estimate against measurement, compound 3: 2.2-fold (0.35 log units) below; measured number above the stated range.
By their numbers in this assay, from the lowest: compounds 1 and 2 (each within the scatter of the next); then compound 3.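

In this assay, methyl in place of hydrogen on a saturated ring carbon of the three-membered ring gives a 2.5-fold higher number from compound 2 to compound 3 (0.39 log units; beyond the scatter), the first step beyond the scatter among these compounds. The cyclopropylsulfonyl group is thus a place where this read-out responds to a single added carbon, unlike the fluoro change, which gave only a 1.1-fold higher number from compound 1 to compound 2 (0.02 log units; within the scatter). Nothing shown bears on the reason for this rise. Going by these compounds, whether an ethyl group or a cyclobutyl ring would carry the number further stays open, as does whether the same methyl gives a similar step on compound 1.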